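The source may report more compounds than this note shows. Statements on the series, on what has been measured and on what is new or still open speak of the compounds shown alone.

Measured so far in an assay on cells for binding affinity to 5-hydroxytryptamine receptor 1B (Homo sapiens), read by radioligand binding; a higher number here means a weaker inhibitor, a lower number a stronger inhibitor:
- compound 1 `NC(=O)c1ccc2c(c1)CCOC2CCN1CC=C(c2csc3cc(F)ccc23)CC1`: 186 nM
- compound 2 `NC(=O)c1ccc2c(c1)CCOC2CCN1CC=C(c2[nH]nc3cc(F)ccc23)CC1`: 210 nM
- compound 3 `NC(=O)c1ccc2c(c1)CCOC2CCN1CC=C(c2c[nH]c3c(Cl)c(Cl)ccc23)CC1`: > 1000 nM

Compound 3 stands apart from the other two: its result is only a limit of the assay, (the limit of > 1000 nM in this assay, at which 1 of the 3 values shown sits), not a number. Compound 4 `NC(=O)c1ccc2c(c1)CCOC2CCN1CC=C(c2c[nH]c3cc(Cl)ccc23)CC1` differs from compound 3 by hydrogen in place of chloro on an aromatic carbon. Going by the values given here, the only measured step in this assay, a 1.1-fold higher number from compound 1 to compound 2 (0.05 log units; within the scatter), swaps one fused ring for another and says nothing about a chloro group, so no step bears directly on the change to compound 4. Because compound 3 gives only a limit (the limit of > 1000 nM in this assay, at which 1 of the 3 values shown sits), the step to compound 4 can only be read from one side. The step of an at least 1.6-fold lower number from compound 3 to compound 4 (0.22 log units; that floor lies within the scatter) is therefore estimated with wide uncertainty. Compound 4 is expected near 600 nM, between 200 nM and 2000 nM.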

Compound 4, inhibition constant: > 1000 nM
Compound 4 was reported as a limit; the forecaster's own chance of this, stated with the estimate: 35%; middle value at least 1.6-fold (0.22 log units) away from the limit.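

Compound 3 and compound 4 both end at a limit of the assay rather than a number, so the step between them cannot be read, because both sit at the same ceiling: the limit of > 1000 nM in this assay, at which 2 of the 4 values shown sit.

Removing one chloro group therefore does not bring compound 4 level with the other two. The 6-chloro-1H-indol-3-yl group gives an at least 4.7-fold higher number from compound 2 to compound 4 (0.67 log units; beyond the scatter) and an at least 5.3-fold higher number from compound 1 to compound 4 (0.73 log units; beyond the scatter).

On these data alone, it remains open whether hydrogen, a methoxy group or an amine in place of the remaining chloro would lower the number in this assay. Also open, as far as these compounds go, is whether the chloro group or the ring carrying it accounts for this gap.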